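Two Thiophene Amides Compared on HL-60 Cells

A few compounds are considered here, and "the series" means these few. Any claim that something is new, unique, unknown or untested is made for them only; others in the source may bear on it.

Measured compounds:
Compound 1, `NC(=O)c1c(NC(=O)c2ccccc2F)sc2c1CCN(C(=S)Nc1ccccc1Cl)C2`, gives 12500 nM.
Compound 2, `NC(=O)c1c(NC(=O)c2ccc(C(F)(F)F)cc2)sc2c1CCN(C(=S)Nc1ccccc1Cl)C2`, gives 36100 nM.
Compound 3, `NC(=O)c1c(NC(=O)c2ccccc2F)sc2c1CCN(C(=S)Nc1cc(C(F)(F)F)cc(C(F)(F)F)c1)C2`, gives 17900 nM.

In a functional assay on HL-60 cells (Homo sapiens) for antiproliferative activity, with a stated time of 24 h (on this read-out higher numbers stand for weaker inhibition and lower numbers for stronger inhibition), the first two compounds share a core and differ in one place: 4-(trifluoromethyl)phenyl in place of 2-fluorophenyl on a carbonyl carbon. That change produced a 2.9-fold higher number from compound 1 to compound 2 (0.46 log units; beyond the scatter).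

Compound 3 and compound 4, `NC(=O)c1c(NC(=O)c2ccc(C(F)(F)F)cc2)sc2c1CCN(C(=S)Nc1cc(C(F)(F)F)cc(C(F)(F)F)c1)C2`, stand in the same relation to each other. Compound 4 is not yet measured. Within the data shown here, the difference between compound 3 and compound 4 reads (4-(trifluoromethyl)phenyl in place of 2-fluorophenyl on a carbonyl carbon), and it is the same kind of change as the one from compound 1 to compound 2, made on a core that carries a different thiourea portion. How the core of compound 3 differs from the core of compound 1 is not broken down here.

Among the measured compounds shown here, because the earlier change gave a 2.9-fold higher number from compound 1 to compound 2 (0.46 log units; beyond the scatter), a step of similar size is expected from compound 3 to compound 4, namely a 2.5-fold higher number from compound 3 to compound 4 (0.40 log units; beyond the scatter), though with only one earlier example the direction is more secure than the size. On that basis compound 4 is estimated at 45000 nM, within a range from 18000 nM to 110000 nM in this assay.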

Compound 4, half-maximal inhibitory concentration: 16300 nM
Beside the measured number, compound 4's estimate is 2.8-fold (0.44 log units) above it; the measured number lies below the stated range.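

In this assay, putting 4-(trifluoromethyl)phenyl in place of 2-fluorophenyl on the carbonyl carbon gave a 1.1-fold lower number from compound 3 to compound 4 (0.04 log units; within the scatter), so on this core the two compounds cannot be told apart. The change therefore did not carry over from the core of compound 1 to the core of compound 3 with the same size, and the two results differ by more than repeat measurements would explain: the same change on two cores in this assay, a 2.9-fold higher number (0.46 log units; beyond the scatter) from compound 1 to compound 2 and a 1.1-fold lower number (0.04 log units; within the scatter) from compound 3 to compound 4, 3.2-fold (0.50 log units) apart, beyond the scatter of two such steps. This does not show why the two cores respond differently, and with a single pair of compounds on each core, it gives no general rule for the series.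

Going by these compounds, it remains open how the same change would read on a core with a third thiourea portion, which would show whether compound 1 and compound 2 or compound 3 and compound 4 are the more typical pair. Also open, on these data alone, is how an amine or a carboxylic acid in place of the trifluoromethyl group would read in this assay.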